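The source may hold more compounds than are shown below. What is called first, only, known or untested is meant among the compounds shown, and "the series" means these compounds.

In a functional assay on MCF7 cells (Homo sapiens) for antiproliferative activity, read by MTT assay, with a stated time of 48 h; a higher number here means a weaker inhibitor, a lower number a stronger inhibitor:
- compound 1 `N=C(N)N/N=C(/C=C/c1ccc(Br)cc1)c1ccccc1`: 250 nM
- compound 2 `N=C(N)N/N=C(/C=C/c1ccc(-c2ccccc2)cc1)c1ccccc1`: 800 nM

Compound 1 holds the lower of these two numbers. Compound 3 `N=C(N)N/N=C(/C=C/c1ccccc1F)c1ccccc1` is still unmeasured, and its change from compound 1 is 2-fluorophenyl in place of 4-bromophenyl on a double-bonded chain carbon bound to a double-bonded chain carbon. Within the data shown here, only one measured step bears on this, a 3.2-fold higher number from compound 1 to compound 2 (0.51 log units; beyond the scatter), a modest change beyond the scatter that replaces bromo with phenyl on an aromatic carbon. Among the measured compounds shown here, no measured compound carries fluorine, so the guide is weak. A similarly modest rise is expected in this assay, an estimated 1.8-fold higher number from compound 1 to compound 3 (0.26 log units; within the scatter). For compound 3 the estimate is 450 nM, with an expected range of 130 nM to 1500 nM.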

Compound 3, half-maximal inhibitory concentration: 3900 nM
Compound 3: the middle estimate sits 8.7-fold (0.94 log units) below what was measured; the measured number lies above the stated range.
By their numbers in this assay, from the lowest: compound 1; then compound 2; then compound 3.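

At this position the number moves strongly with the aryl group, as this assay shows a large step (a 16-fold higher number from compound 1 to compound 3 (1.19 log units; beyond the scatter)), although 4-bromophenyl and 2-fluorophenyl have the same count of heavy atoms and each carries one aromatic ring. This exchange moved the number further than the modest step that put phenyl in place of bromo (a 3.2-fold higher number from compound 1 to compound 2 (0.51 log units; beyond the scatter)). Nothing measured here accounts for the change.

Going by these compounds, what a 4-fluorophenyl or a 2-bromophenyl group would give stays open, and with it whether the halogen or its place carries the rise. On these data alone, the effect of an amine on this aromatic ring also remains open.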